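The source may report more compounds than this note shows. Statements on the series, on what has been measured and on what is new or still open speak of the compounds shown alone.

Working notes on the series. Compound 1 `CC(C(=O)NCc1ccc(C(F)(F)F)cc1N1CCC(c2ccc(F)cc2)CC1)c1ccc(NS(C)(=O)=O)c(F)c1` and compound 2 `CC(C(=O)NCc1ccc(C(F)(F)F)cc1OCc1ccccc1)c1ccc(NS(C)(=O)=O)c(F)c1` share a common core and differ only in the group carried on one aromatic carbon of that core. In an assay on CHO cells for antagonist activity at transient receptor potential cation channel subfamily V member 1 (Homo sapiens), read by FLIPR (a higher number here means a weaker inhibitor, a lower number a stronger inhibitor), compound 1 gives 0.9 nM. In this assay compound 2 gives 0.9 nM, level with compound 1; the two values lie within the scatter of each other, so no order between them can be read from these numbers.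

Compound 3 `CC(C(=O)NCc1ccc(C(F)(F)F)cc1-c1ccc(F)c(Cl)c1)c1ccc(NS(C)(=O)=O)c(F)c1` has not yet been measured in this assay. It keeps the core of compound 2 and changes one group: 3-chloro-4-fluorophenyl in place of benzyloxy on an aromatic carbon. Among the measured compounds shown here, no measured pair shows this particular exchange, so the size of the step rests on the two neighbours alone. Since compound 1 at 0.9 nM and compound 2 at 0.9 nM sit at the same level with two quite different groups on this carbon, the step from compound 2 to compound 3 is expected to be small, a 1.7-fold higher number from compound 2 to compound 3 (0.22 log units; within the scatter), in no clear direction beyond the scatter. Compound 3 is estimated in this assay at 1.5 nM, with a likely range from 0.4 nM to 6 nM.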

Compound 3, inhibition constant: 0.6 nM
Estimate against measurement, compound 3: 2.5-fold (0.40 log units) above; the measured number falls inside the stated range.
By their numbers in this assay, from the lowest: compounds 3, 1 and 2 (each within the scatter of the next).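

On this aromatic carbon, ortho to a large group and meta to a trifluoromethyl group, 3-chloro-4-fluorophenyl in place of benzyloxy gives a 1.5-fold lower number from compound 2 to compound 3 (0.18 log units; within the scatter) in this assay and so leaves the read-out level within the scatter. The exchange removes the hydrogen-bond acceptor counted on benzyloxy, and 3-chloro-4-fluorophenyl carries none, so in this pair a value at this level does not depend on that acceptor. This adds a third group at this carbon to the two already level in the series, and the compounds give no information on why such different groups read alike.

All three groups compared here are large and each holds an aromatic ring of carbon only, so the compounds shown do not define how much of this group the read-out needs, or whether a value at this level would survive a plain hydrogen, a methyl, an amine or a carboxylic acid on this carbon. The separate roles of the chlorine and the fluorine on the entering ring also stay open, as neither the unsubstituted phenyl nor a singly halogenated phenyl stands among these compounds.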